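Fluoropyridine in place of a ring: expected permeability

The source may hold more compounds than are shown below. What is called first, only, known or untested is meant among the compounds shown, and "the series" means these compounds.

In an ADME assay on LLC-PK1 cells (Sus scrofa) for permeability, read by LC-MS, with a stated time of 2 h, tested at 5 uM (a lower number here means that the compound crosses the layer more slowly, a higher number that the compound crosses the layer faster), compound 2 `CC#Cc1cncc(-c2ccc3c(c2)[C@@]2(COC(N)=N2)c2cc(C4=CCCOC4)ncc2O3)c1` gives 19 nm/s, the second highest of three numbers. Compound 1 `CC#Cc1cncc(-c2ccc3c(c2)[C@@]2(COC(N)=N2)c2cc(Cl)ncc2O3)c1` gives 22 nm/s, and compound 3 `NC1=N[C@@]2(CO1)c1cc(-c3cncc(C#CC4CC4)c3)ccc1Oc1cnc(C3=CCOCC3)cc12` gives 13 nm/s; both values sit within the scatter of compound 2. Within the data shown here, compound 4 `CC#Cc1cncc(-c2ccc3c(c2)[C@@]2(COC(N)=N2)c2cc(-c4ccnc(F)c4)ncc2O3)c1` differs from compound 2 in one place: a group of 7 heavy atoms (5 carbon, 1 nitrogen, 1 fluorine; one six-membered aromatic ring with 1 hetero atom) in place of a group of 6 heavy atoms (5 carbon, 1 oxygen; one six-membered non-aromatic ring with 1 hetero atom), on an aromatic carbon The only measured step at that same place, a 1.2-fold lower number from compound 1 to compound 2 (0.06 log units; within the scatter), stayed within the scatter, and no measured step shows an aromatic ring entering there. With that single guide, the step is expected to be a 1.1-fold higher number from compound 2 to compound 4 (0.02 log units; within the scatter), none beyond the scatter. Compound 4 is therefore estimated at 20 nm/s in this assay, with a range from 10 nm/s to 40 nm/s.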

Compound 4, apparent permeability: 15 nm/s
For compound 4 the middle estimate is 1.3-fold (0.12 log units) above the measured one; measured number inside the range.
By their numbers in this assay, from the lowest: compounds 3, 4, 2 and 1 (each within the scatter of the next).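

At this aromatic carbon, 2-fluoropyridin-4-yl brings in the first aromatic ring, and in this assay it gives a 1.3-fold lower number from compound 2 to compound 4 (0.10 log units; within the scatter) when it takes the place of the non-aromatic ring and a 1.5-fold lower number from compound 1 to compound 4 (0.17 log units; within the scatter) when it takes the place of chloro. Chloro, a non-aromatic ring and an aromatic ring thus all give numbers within the scatter of one another at this place. Nothing available here explains these small steps.

As far as these compounds go, whether a primary amine or a carboxylic acid at this carbon would give a step beyond the scatter remains open. So does what the fluorine contributes, which only a comparison with plain pyridin-4-yl could show.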